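Swapping an aryl for a diisopropylamino chain in the core

This account rests on a few compounds, and the source may have more. Where it says the series, first, only, none or still open, it means among the compounds named here.

Compound 1 `Cc1cccc(Cn2ccc3nc(-c4ccccc4)nc-3c2)c1`: in an ADME assay on MDBK cells (Bos taurus) for cytotoxicity (on this read-out lower numbers stand for higher toxicity in this test and higher numbers for lower toxicity in this test), compound 1 gives > 100000 nM, a limit of the assay.
Compound 2 `Brc1ccccc1Cn1ccc2nc(-c3ccccc3)nc-2c1`: in this assay compound 2 gives > 100000 nM, again a limit.
Compound 3 `Ic1ccc(Cn2ccc3nc(-c4ccccc4)nc-3c2)cc1`: in this assay compound 3 gives 22000 nM.

Compound 1 stands at the limit of > 100000 nM in this assay, at which 2 of the 3 values shown sit, so its number is known only as that limit. Compound 4 `CC(C)N(CCn1ccc2nc(-c3ccccc3)nc-2c1)C(C)C` carries (diisopropylamino)methyl in place of 3-methylphenyl on a saturated chain carbon bound to an aromatic nitrogen. Among the measured compounds shown here, no measured step covers this change. The aryl swaps gave a step that the two limits leave unreadable from compound 1 to compound 2 and an at least 4.5-fold lower number from compound 1 to compound 3 (0.65 log units; beyond the scatter), with an at least 4.5-fold lower number from compound 2 to compound 3 (0.65 log units; beyond the scatter); the readable steps ran towards lower numbers. Compound 4 leaves the ring altogether, so these steps guide only loosely. Compound 4 is expected to sit near the limit or a little under it, the step of an at least 1.2-fold lower number from compound 1 to compound 4 (0.09 log units; that floor lies within the scatter) being the expectation. The estimate for compound 4 is 80000 nM, expected between 20000 nM and 200000 nM.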

Compound 4, half-maximal cytotoxic concentration: > 100000 nM
Compound 4: no number, only a limit; the forecaster's own chance of this, stated with the estimate: 55%; at least 1.2-fold (0.09 log units) between middle value and limit.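

In this assay, the move away from an aromatic ring on a saturated chain carbon bound to an aromatic nitrogen gives an at least 4.5-fold higher number from compound 3 to compound 4 (0.65 log units; beyond the scatter). The lower number of compound 3 therefore does not extend to (diisopropylamino)methyl, a group with no ring. The steps to compound 4 from compound 1 and compound 2 cannot be read, and compound 4 joins them at a limit: the limit of > 100000 nM in this assay, at which 3 of the 4 values shown sit.

From the compounds shown here alone, how far these three compounds lie from that limit stays open. So does the outcome for a morpholine or a carboxylic acid at this place.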